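Swapping a methyl for chlorine on the benzyl ring

The source may report more compounds than this note shows. Statements on the series, on what has been measured and on what is new or still open speak of the compounds shown alone.

Of the compounds shown here, three built on one shared core have been tested in a functional assay on MCF7 cells (Homo sapiens) for cytotoxicity, read by MTT assay, with a stated time of 72 h; on this read-out higher numbers stand for weaker inhibition and lower numbers for stronger inhibition. Compound 1 `Cc1cccc(CSc2cc(Cl)c(C)cc2S(=O)(=O)/N=C(\N)n2nccc2-c2ccccc2)c1` gives 47000 nM. Compound 3 `Cc1cc(-c2ccccc2)n(/C(N)=N/S(=O)(=O)c2cc(C)c(Cl)cc2SCc2ccccc2C)n1` gives 80000 nM, a number within the usual scatter of that of compound 1, while compound 2 `Cc1cccc(CSc2cc(Cl)c(C)cc2S(=O)(=O)/N=C(\N)n2nc(C)cc2-c2ccccc2)c1` gives 105000 nM, which lies beyond it. The step of a 2.2-fold higher number from compound 1 to compound 2 (0.35 log units; beyond the scatter) comes from a methyl in place of hydrogen on an aromatic carbon. The step of a 1.3-fold lower number from compound 2 to compound 3 (0.12 log units; within the scatter) alters the benzyl ring attached to the sulfur and stays within the scatter.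

Compound 4 `Cc1cc(S(=O)(=O)/N=C(\N)n2nccc2-c2ccccc2)c(SCc2ccccc2Cl)cc1Cl` differs from compound 1 by 2-chlorophenyl in place of 3-methylphenyl on a saturated chain carbon bound to a sulfur. Among the compounds with values here, of the measured steps, only the one from compound 2 to compound 3 bears on this, as it changes the same ring at the same place, and it stayed within the scatter; no measured step puts chlorine on that ring. The expectation is therefore a step of no more than the scatter, a 1.0-fold lower number from compound 1 to compound 4 (0.02 log units; within the scatter). Compound 4 is estimated at 45000 nM, with a range from 15000 nM to 130000 nM.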

Compound 4, half-maximal inhibitory concentration: 24000 nM
Estimate against measurement, compound 4: 1.9-fold (0.27 log units) above, within the range that was stated.
By their numbers in this assay, from the lowest: compounds 4, 1, 3 and 2 (each within the scatter of the next, the first and the last beyond it).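

In this assay, putting 2-chlorophenyl in place of 3-methylphenyl on the saturated chain carbon bound to a sulfur gives a 2.0-fold lower number from compound 1 to compound 4 (0.29 log units; within the scatter), a step that stays within the usual scatter. The earlier compounds shown here only showed the methyl on this ring being placed differently, whereas this step shows that a chlorine-bearing ring can also sit here without a change that clears the scatter, at least on the core of compound 1. No measurement shown here explains this result.

Because the step swaps methyl for chlorine and alters the ring position in one move, the effects of the two changes cannot be separated. From the compounds shown here alone, it also remains open whether a benzyl ring carrying an amine or a carboxylic acid, or a longer chain in place of the benzyl group, would give a step beyond the scatter.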